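This account rests on a few compounds, and the source may have more. Where it says the series, first, only, none or still open, it means among the compounds named here.

Working notes on the series, all read in a physicochemical assay for solubility, in phosphate buffer, with a stated time of 18 h, at pH 7.4; on this read-out lower numbers stand for lower solubility and higher numbers for higher solubility. Compound 1 `COc1cc2ncnc(-n3nc(-c4ccccn4)nc3N)c2cc1[N+](=O)[O-]` gives 2000 nM and compound 2 `COc1cc2ncnc(-n3nc(-c4ccccn4)nc3N)c2cc1N` gives 3000 nM; the step between them is a 1.5-fold higher number from compound 1 to compound 2 (0.18 log units; within the scatter). Compound 3 `COc1cc2ncnc(-n3nc(-c4ccccn4)nc3N)c2cc1OCCCN1CC(C)OC(C)C1` stands highest of the three at 8000 nM.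

The next change leads to compound 4 `COc1cc2ncnc(-n3nc(-c4ccccn4)nc3N)c2cc1OCCCCNC(=O)OC(C)(C)C`, with ((tert-butoxycarbonyl)amino)methyl in place of 2,6-dimethylmorpholin-4-yl on a saturated chain carbon, three bonds along the chain from an oxygen on an aromatic ring.

Going by the values given here, no measured step makes this exchange. The closest evidence is the pair of modest steps that bring in 3-(2,6-dimethylmorpholin-4-yl)propoxy: a 4.0-fold higher number from compound 1 to compound 3 (0.60 log units; beyond the scatter) and a 2.7-fold higher number from compound 2 to compound 3 (0.43 log units; beyond the scatter). These compounds do not separate the contribution of the chain from that of the ring, and compound 4 keeps a chain but loses the ring. A modest downward move of similar size is therefore expected, though with wide uncertainty. The expected step is a 2.7-fold lower number from compound 3 to compound 4 (0.43 log units; beyond the scatter). For compound 4 the estimate is 3000 nM, with an expected range of 1000 nM to 7000 nM.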

Compound 4, solubility: 500 nM
Beside the measured number, compound 4's estimate is 6.0-fold (0.78 log units) above it, outside the stated range (below it).
By their numbers in this assay, from the lowest: compound 4; then compounds 1 and 2 (each within the scatter of the next); then compound 3.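

In this assay, going by these compounds alone, ((tert-butoxycarbonyl)amino)methyl in place of 2,6-dimethylmorpholin-4-yl gives a 16-fold lower number from compound 3 to compound 4 (1.20 log units; beyond the scatter), the only large step so far, so the number at this position depends strongly on what ends the chain. A chain alone does not go with a higher number: compound 3 stands above compound 1 and compound 2, whereas compound 4, at 500 nM, stands under compound 1 at 2000 nM and compound 2 at 3000 nM. No measurement in hand bears on the reason for this step.

The compounds shown change the chain length and the end group together, leaving their separate shares open. A 4-aminobutyl group, or 2,6-dimethylmorpholin-4-yl carried on a butyl chain, would help to separate them.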